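A few compounds are considered here, and "the series" means these few. Any claim that something is new, unique, unknown or untested is made for them only; others in the source may bear on it.

Three close relatives have been tested in an ADME assay on HepG2 cells (Homo sapiens) for cytotoxicity, read by luminescence, CellTiter-Glo and ATP content, with a stated time of 72 h; on this read-out lower numbers stand for an effect already at smaller amounts and higher numbers for an effect only at larger amounts of compound. Compound 1 `c1ccc(CCc2ccc3c(NCCCNCc4ccco4)ccnc3c2)cc1` gives 16000 nM. Compound 2 `CN(C)c1cccc(Oc2ccc3c(NCCCNCc4ccco4)ccnc3c2)c1` carries a 3-(dimethylamino)phenoxy group where compound 1 carries a phenethyl group, and in this assay compound 2 gives 16000 nM; the step between the two is no change at the digits printed from compound 1 to compound 2 (within the scatter). Compound 3 `COc1cccc(CNCCCNc2ccnc3cc(Oc4cccc(N(C)C)c4)ccc23)c1O` keeps the 3-(dimethylamino)phenoxy group but has a 2-hydroxy-3-methoxyphenyl group in place of furan-2-yl on the side chain, and in this assay compound 3 gives 7300 nM, the lowest of the three numbers, reached by a modest step of a 2.2-fold lower number from compound 2 to compound 3 (0.34 log units; beyond the scatter).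

Compound 4 `COc1cccc(CNCCCNc2ccnc3cc(CCc4ccccc4)ccc23)c1O` keeps the side chain of compound 3 and differs from it by phenethyl in place of 3-(dimethylamino)phenoxy on an aromatic carbon. Within the data shown here, the one measured step that bears on this exchange is no change at the digits printed from compound 1 to compound 2 (within the scatter), where the same two groups were swapped in the opposite direction on a pair carrying the furan-2-yl side chain, and nothing moved beyond the scatter. On that basis the expected step is a 1.1-fold higher number from compound 3 to compound 4 (0.04 log units; within the scatter), that is, no shift beyond the scatter in either direction. Compound 4 is therefore estimated at 8000 nM in this assay, with a likely range from 4000 nM to 16000 nM.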

Compound 4, half-maximal effective concentration: 6800 nM
Estimate against measurement, compound 4: 1.2-fold (0.07 log units) above, and the stated range covers the measured number.
By their numbers in this assay, from the lowest: compounds 4 and 3 (each within the scatter of the next); then compounds 1 and 2 (each within the scatter of the next).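

In this assay, the exchange of 3-(dimethylamino)phenoxy for phenethyl on this aromatic carbon again moves nothing beyond the scatter, a 1.1-fold lower number from compound 3 to compound 4 (0.03 log units; within the scatter), so the earlier flat result was not confined to the furan-2-yl side chain and also holds with the 2-hydroxy-3-methoxyphenyl side chain: the same change on two cores in this assay, no change at the digits printed (within the scatter) from compound 1 to compound 2 and a 1.1-fold higher number (0.03 log units; within the scatter) from compound 4 to compound 3, 1.1-fold (0.03 log units) apart, within the scatter of two such steps

The side-chain change, earlier seen only with 3-(dimethylamino)phenoxy on the core, now recurs with phenethyl, a 2.4-fold lower number from compound 1 to compound 4 (0.37 log units; beyond the scatter), and the two steps are of matching size: the same change on two cores in this assay, a 2.2-fold lower number (0.34 log units; beyond the scatter) from compound 2 to compound 3 and a 2.4-fold lower number (0.37 log units; beyond the scatter) from compound 1 to compound 4, 1.1-fold (0.03 log units) apart, within the scatter of two such steps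

Across these four compounds, with none going against it, the two changes therefore behave independently: the side chain accounts for the modest shift in the number, while the exchange on the aromatic carbon leaves it in place.

From the compounds shown here alone, what remains open is whether this flat behaviour reaches beyond two large groups that both carry a carbon-only aromatic ring, for instance to a carboxylic acid or a morpholine on the same carbon. On the side chain, only two aryl groups are shown, so it is also unknown whether a pyridine ring or a longer chain would carry the number further in either direction.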